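Swapping methoxy patterns on the benzoyl ester

This account rests on a few compounds, and the source may have more. Where it says the series, first, only, none or still open, it means among the compounds named here.

- compound 1 `COC(=O)/C(=C\c1ccc(OC(=O)c2ccc(OC)c(OC)c2)cc1)Sc1ccnc2cc(Cl)ccc12`: 51100 nM
- compound 2 `COC(=O)/C(=C\c1ccc(OC(=O)c2ccc(OC)cc2OC)cc1)Sc1ccnc2cc(Cl)ccc12`: 41600 nM

In an ADME assay on cells (Lymphocyte, Homo sapiens) for cytotoxicity, read by MTT assay, with a stated time of 48 h (a lower number here means a stronger inhibitor, a higher number a weaker inhibitor), compound 2 gives 41600 nM, and compound 1 lies within the usual scatter of that number. Compound 3 `COC(=O)/C(=C\c1ccc(OC(=O)c2cc(OC)c(OC)c(OC)c2)cc1)Sc1ccnc2cc(Cl)ccc12` keeps the shared core but carries a new group: 3,4,5-trimethoxyphenyl in place of 2,4-dimethoxyphenyl on a carbonyl carbon. Among the compounds with values here, only one measured step bears on this change, a 1.2-fold lower number from compound 1 to compound 2 (0.09 log units; within the scatter), an exchange at the same place that stayed within the scatter. Within the data shown here, the one group added here has not been tested, so no step beyond the scatter is expected, and the estimated step is a 1.1-fold higher number from compound 2 to compound 3 (0.03 log units; within the scatter). For compound 3 the expected value is 45000 nM, within an estimated range of 20000 nM to 95000 nM.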

Compound 3, half-maximal inhibitory concentration: 35200 nM
The estimate for compound 3 lay 1.3-fold (0.11 log units) above the measured number; the measured number falls inside the stated range.
By their numbers in this assay, from the lowest: compounds 3, 2 and 1 (each within the scatter of the next).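

Putting 3,4,5-trimethoxyphenyl in place of 2,4-dimethoxyphenyl on the carbonyl carbon gives a 1.2-fold lower number from compound 2 to compound 3 (0.07 log units; within the scatter) and so this position takes a larger group with no readable shift in the number. Methoxy in place of hydrogen on an aromatic carbon gives a 1.5-fold lower number from compound 1 to compound 3 (0.16 log units; within the scatter) and so an added methoxy, not only a rearranged one, also stays within the scatter across these three compounds. No measurement is available that could explain this result.

Going by these compounds, whether the number would stay this flat with a ring carrying an amine or a carboxylic acid remains open. So does the result of replacing the methoxy groups with longer chains.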